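From formyloxy to acetoxy on a shared sulfone core

The compounds below may be only part of what the source reports. "The series", "measured", "known", "first", "only" and "open" are said of these compounds alone.

Compound 1 `CO[C@H]1C(=O)N2C(C(=O)C(C)(C)C)=C(C)[C@@H](Sc3nnnn3C)S(=O)(=O)C12` and compound 2 `CO[C@H]1C(=O)N2C(C(=O)C(C)(C)C)=C(C)[C@@H](OC=O)S(=O)(=O)C12` share one core and differ only in the group on a saturated ring carbon. In a physicochemical assay, at pH 7.4 (a lower number here means that the compound disappears faster, a higher number that the compound lasts longer), compound 1 gives 18 h. For compound 2 the result in this assay is only a limit, < 0.5 h, not a measured number. Compound 2 therefore stands at the short-lived end of the two results known so far, and the step of an at least 36-fold lower number from compound 1 to compound 2 (1.55 log units; beyond the scatter) is large. Compound 3 `CO[C@H]1C(=O)N2C(C(=O)C(C)(C)C)=C(C)[C@@H](OC(C)=O)S(=O)(=O)C12` is the next change: methyl in place of hydrogen on a carbonyl carbon. Going by the values given here, no measured step covers a change of this kind; the only step known, an at least 36-fold lower number from compound 1 to compound 2 (1.55 log units; beyond the scatter), exchanges the whole group on the ring carbon and so gives little guidance. A small step, an at least 2.0-fold higher number from compound 2 to compound 3 (0.30 log units; that floor lies within the scatter), is expected, possibly none beyond the scatter. Compound 3 is expected to give about 1 h in this assay, with a likely range from 0.3 h to 4 h.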

Compound 3, half-life: 6.3 h
Beside the measured number, compound 3's estimate is 6.3-fold (0.80 log units) below it; the whole stated range lies below it.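

On this saturated ring carbon, one added methyl on the carbonyl carbon, which turns formyloxy into acetoxy, gives an at least 12-fold higher number from compound 2 to compound 3 (1.10 log units; beyond the scatter) in this assay, so a very small change at the far end of the group has a large effect. That size is only a floor, since the result for compound 2 is a limit and not a number: the limit of < 0.5 h in this assay, at which 1 of the 3 values shown sits. Acetoxy in place of (1-methyl-1H-tetrazol-5-yl)sulfanyl gives a 2.9-fold lower number from compound 1 to compound 3 (0.46 log units; beyond the scatter), so a group joined through oxygen at this place need not be as short-lived as formyloxy.

Formyloxy and acetoxy alone cannot show whether a longer chain, such as propionyloxy, or a branched pivaloyloxy would last longer still. Also open, from the compounds shown here alone, is how a carbamate built from an amine would behave here, and what underlies the large step.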